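This account rests on a few compounds, and the source may have more. Where it says the series, first, only, none or still open, it means among the compounds named here.

For the measured compounds named here, compound 2 `Cc1cccc(C)c1-c1cccc(COc2ccc(CC3SC(=O)NC3=O)s2)c1` gives 82 nM in a functional assay on cells for agonist activity at Free fatty acid receptor 1 (Homo sapiens), read by calcium flux (on this read-out higher numbers stand for an effect only at larger amounts of compound and lower numbers for an effect already at smaller amounts), the highest of the two numbers so far; its nearest neighbour is compound 1 `Cc1cccc(C)c1-c1cccc(COc2ccc(CCC(=O)O)s2)c1`, which in this assay gives 32 nM. Going by the values given here, the single step measured, a 2.6-fold higher number from compound 1 to compound 2 (0.41 log units; beyond the scatter), is the only one that bears on the change considered here. Compound 3 `Cc1cccc(C)c1-c1cccc(COc2ccc(C(CC(=O)O)C3CC3)s2)c1` differs from compound 2 by 2-carboxy-1-cyclopropylethyl in place of (2,4-dioxo-1,3-thiazolidin-5-yl)methyl on an aromatic carbon. Among the compounds with values here, this change reverses the one measured step in kind, bringing a carboxy-bearing chain back, while also adding the cyclopropyl branch, for which no step exists. The expected step in this assay is therefore a return toward the number of compound 1, a 2.3-fold lower number from compound 2 to compound 3 (0.37 log units; beyond the scatter), within the modest size seen in the measured step, since nothing else in the data supports a larger move. Compound 3 is estimated at 35 nM, with a range from 10 nM to 120 nM.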

Compound 3, half-maximal effective concentration: 3920 nM
Compound 3: the middle estimate sits 110-fold (2.05 log units) below what was measured; the whole stated range lies below it.
By their numbers in this assay, from the lowest: compound 1; then compound 2; then compound 3.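

In this assay the saturated chain carbon bound to the aromatic carbon proves far less forgiving than the earlier data indicated: cyclopropyl in place of hydrogen there gives a 120-fold higher number from compound 1 to compound 3 (2.09 log units; beyond the scatter) against only a 2.6-fold higher number from compound 1 to compound 2 (0.41 log units; beyond the scatter) for the earlier change in this part of the molecule. A carboxy-bearing chain alone therefore does not restore the number of compound 1, since 2-carboxy-1-cyclopropylethyl in place of (2,4-dioxo-1,3-thiazolidin-5-yl)methyl gives a 48-fold higher number from compound 2 to compound 3 (1.68 log units; beyond the scatter) on this aromatic carbon next to the ring sulfur. Nothing available accounts for the size of these steps.

Still open, as far as these compounds go, is whether the loss belongs to the cyclopropyl ring in particular or to any branch on this chain carbon, such as a methyl or a hydroxyl. Also open, from the compounds shown here alone, is how a branch one carbon closer to the carboxylic acid would read.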